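Five-membered to six-membered aryl swap at the third position

The compounds below may be only part of what the source reports. "The series", "measured", "known", "first", "only" and "open" are said of these compounds alone.

The three measured compounds share one core, carrying two 4-hydroxyphenyl groups and a varied third aryl group. Compound 1 `Oc1ccc(-c2cc(-c3cccs3)cc(-c3ccc(O)cc3)n2)cc1` gives 86.3% in an assay on isolated protein for inhibition of DNA topoisomerase 1 (Homo sapiens), with a stated time of 30 min, tested at 100 uM; on this read-out lower numbers stand for a weaker effect and higher numbers for a stronger effect at the one concentration tested. Compound 2 `Oc1ccc(-c2cc(-c3ccoc3)cc(-c3ccccc3O)n2)cc1` gives 30.1% in this assay. Compound 3 `Oc1ccc(-c2cc(-c3ccoc3)cc(-c3ccc(O)cc3)n2)cc1` gives 74.9% in this assay, which places it second highest of the three: a number 11.4 percentage points lower from compound 1 to compound 3 (beyond the scatter), and a number 44.8 percentage points higher from compound 2 to compound 3 (beyond the scatter).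

Compound 4 `Oc1ccc(-c2cc(-c3ccccn3)cc(-c3ccc(O)cc3)n2)cc1` is not yet measured. It differs from compound 3 in one place: pyridin-2-yl in place of furan-3-yl on an aromatic carbon. Going by the values given here, only the step from compound 1 to compound 3 touches the same position, and there the swap of one five-membered aryl for another gave a modest change, a number 11.4 percentage points lower from compound 1 to compound 3 (beyond the scatter). The step from compound 2 to compound 3 concerns a different position and does not bear on this change. Among the compounds with values here, no measured compound carries a pyridin-2-yl group, so the direction cannot be read from the series. A modest step, a number 0.9 percentage points lower from compound 3 to compound 4 (within the scatter), is expected, with compound 4 estimated at 74%, in the range 52% to 92%.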

Compound 4, a percentage reported as inhibition, at one concentration (the size of the read-out at that concentration, not a potency): 1.4%
Compound 4: the middle estimate sits 72.6 percentage points above what was measured; measured number below the stated range.
By their numbers in this assay, from the lowest: compound 4; then compound 2; then compound 3; then compound 1.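

At this position the choice of aryl group matters far more than the swap of one five-membered aryl for another suggested. In this assay, that swap gave the modest a number 11.4 percentage points lower from compound 1 to compound 3 (beyond the scatter), whereas pyridin-2-yl gives the large a number 73.5 percentage points lower from compound 3 to compound 4 (beyond the scatter) and the large a number 84.9 percentage points lower from compound 1 to compound 4 (beyond the scatter). Among compound 1, compound 3 and compound 4, which all carry two 4-hydroxyphenyl groups, both five-membered aryl groups keep the read-out high and the one six-membered aryl group does not, though no evidence is available to account for this drop.

The compounds shown do not settle whether the drop goes with the six-membered ring or with the ring nitrogen of pyridin-2-yl. A plain phenyl or a pyridin-4-yl group at this position would separate the two.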